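A few compounds are considered here, and "the series" means these few. Any claim that something is new, unique, unknown or untested is made for them only; others in the source may bear on it.

In a functional assay on U-251 cells (Homo sapiens) (a lower number here means a stronger inhibitor of growth, a higher number a weaker inhibitor of growth), compound 1 `N#Cc1ccc(/C=C/S(=O)(=O)Cc2ccc(Nc3ncnc4ccccc34)cc2)cc1` carries a 4-cyanophenyl group and reports only a limit of > 100000 nM rather than an actual number. Among the measured compounds shown here, compound 2 `O=S(=O)(/C=C/c1ccc(Cl)c(Cl)c1)Cc1ccc(Nc2ncnc3ccccc23)cc1` carries a 3,4-dichlorophenyl group in that place and gives 11000 nM as the only actual number so far.

Compound 3 `O=S(=O)(/C=C/c1ccc(Cl)cc1Cl)Cc1ccc(Nc2ncnc3ccccc23)cc1` has 2,4-dichlorophenyl in place of 3,4-dichlorophenyl on a double-bonded chain carbon bound to a double-bonded chain carbon. The two have the same atoms, joined differently: 2,4-dichlorophenyl in place of 3,4-dichlorophenyl on a double-bonded chain carbon bound to a double-bonded chain carbon is the whole change.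

For the measured compounds named here, one measured step bears on this place, and it shows that the group there can move the number: an at least 9.0-fold lower number from compound 1 to compound 2 (0.95 log units; beyond the scatter) is its size, and that size is only a minimum. That step replaced a 4-cyanophenyl group with a dichlorophenyl group, whereas the new change keeps a dichlorophenyl group, so a shift that large is not expected. Going by the values given here, no measured pair compares two dichlorophenyl groups, which leaves the direction open. The expected outcome is a 1.1-fold higher number from compound 2 to compound 3 (0.04 log units; within the scatter) and would lie within the usual scatter. For compound 3 the estimate is 12000 nM with an expected range from 4000 nM to 40000 nM in this assay when it is measured.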

Compound 3, concentration for 50% growth inhibition: 4000 nM
Compound 3: middle estimate off by 3.0-fold (0.48 log units), on the high side; measured number inside the range.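

In this assay, rearranging the chlorines on the ring while keeping the same atoms gives a 2.8-fold lower number from compound 2 to compound 3 (0.44 log units; beyond the scatter), so this position responds not only to which group sits there but also to how that group's chlorines are arranged, something the earlier step from a 4-cyanophenyl group could not show. Against the 4-cyanophenyl group, the 2,4-dichlorophenyl group gives an at least 25-fold lower number from compound 1 to compound 3 (1.39 log units; beyond the scatter), a larger step than the one measured for the 3,4-dichlorophenyl group. Compound 1 gives only a limit, so neither step from it has a known full size: the limit of > 100000 nM in this assay, at which 1 of the 3 values shown sits.

Among the compounds shown here, with only two dichlorophenyl groups to compare, it remains open whether both chlorines are needed, and whether a phenyl ring carrying a single chlorine, two bromines or a methoxy group would match or improve on compound 3. As far as these compounds go, all three compounds also keep the same double-bonded chain and the same core, so it is unknown whether the gain seen with the 2,4-dichlorophenyl group would survive if that chain were replaced by a saturated chain or an amide.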